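From an aryl group to a sulfonamide arm

The source may report more compounds than this note shows. Statements on the series, on what has been measured and on what is new or still open speak of the compounds shown alone.

Two compounds have been measured in a functional assay on MCF7 cells (Homo sapiens) for antiproliferative activity, read by MTT assay, with a stated time of 72 h; on this read-out lower numbers stand for stronger inhibition and higher numbers for weaker inhibition:

compound 1 `CC(C)(C)c1cn(C[C@H](O)[C@H]2OC(=O)C(OCc3ccccc3)=C2OCc2ccccc2)nn1` gives 730 nM
compound 2 `Cc1ccc(-c2cn(C[C@H](O)[C@H]3OC(=O)C(OCc4ccccc4)=C3OCc3ccccc3)nn2)cc1` gives only a limit of the assay, > 100000 nM

Compound 2 therefore stands at the limit (the limit of > 100000 nM in this assay, at which 1 of the 2 values shown sits), and no number is known for it. Within the data shown here, the one measured step is an at least 130-fold higher number from compound 1 to compound 2 (2.13 log units; beyond the scatter), which shows that exchanging tert-butyl for 4-methylphenyl on the shared core removed the measurable effect.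

Compound 3 `Cc1ccc(S(=O)(=O)NCc2cn(C[C@H](O)[C@H]3OC(=O)C(OCc4ccccc4)=C3OCc3ccccc3)nn2)cc1` differs from compound 2 by (((4-methylphenyl)sulfonyl)amino)methyl in place of 4-methylphenyl on an aromatic carbon. Among the measured compounds shown here, no measured step covers this change; the only step on record, from compound 1 to compound 2, concerns the same position but a different pair of groups, so it gives direction only loosely. Since compound 2 sits at a limit, any number for compound 3 would be a gain relative to it, but the size cannot be read from the data. The expected step in this assay is estimated as an at least 3.3-fold lower number from compound 2 to compound 3 (0.52 log units; beyond the scatter), with a fair chance that the assay again reports only a limit. For compound 3 the estimated value is 30000 nM, within a range from 3000 nM to 200000 nM.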

Compound 3, half-maximal inhibitory concentration: 6400 nM
For compound 3 the middle estimate is 4.7-fold (0.67 log units) above the measured one, within the range that was stated.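

The result shows that a 4-methylphenyl ring is not ruled out at this position: when the ring sits at the end of the (((4-methylphenyl)sulfonyl)amino)methyl arm, a measurable number returns in this assay, with an at least 15-fold lower number from compound 2 to compound 3 (1.19 log units; beyond the scatter). Compound 2 is only a limit and not a number, so the size of this step is a minimum: the limit of > 100000 nM in this assay, at which 1 of the 3 values shown sits.

The arm still does not match tert-butyl, with an 8.8-fold higher number from compound 1 to compound 3 (0.94 log units; beyond the scatter), and of the three groups shown, tert-butyl on the shared core gives the lowest number.

The compounds shown do not tell which part of the arm carries the gain, whether the sulfonyl and amino link, the methyl link or the 4-methylphenyl ring at its end. A plain aminomethyl group, an arm ending in a cyclohexyl ring and a simple straight alkyl chain at this position would each help to separate these parts, and would also show whether anything here can come close to tert-butyl.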